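The compounds below may be only part of what the source reports. "The series", "measured", "known", "first", "only" and "open" are said of these compounds alone.

In a functional assay on HUVEC cells (Homo sapiens) for antiproliferative activity, read by MTT assay, with a stated time of 48 h (on this read-out lower numbers stand for stronger inhibition and higher numbers for weaker inhibition), compound 1 (`Brc1cccc(/C=C/c2nnc(-c3ccc4c(c3)OCCO4)o2)c1`) gives 13500 nM, compound 2 (`Fc1ccccc1/C=C/c1nnc(-c2ccc3c(c2)OCCO3)o1`) gives 1160 nM and compound 3 (`Clc1ccc(/C=C/c2nnc(-c3ccc4c(c3)OCCO4)o2)cc1`) gives 8030 nM. Compound 3 thus lies within the scatter of compound 1, and its number is clearly higher than that of compound 2. Compound 4 (`Cc1ccccc1/C=C/c1nnc(-c2ccc3c(c2)OCCO3)o1`) is unmeasured, and it differs from compound 3 as follows: 2-methylphenyl in place of 4-chlorophenyl on a double-bonded chain carbon bound to a double-bonded chain carbon. Compound 2 carries 2-fluorophenyl, the closest match to the entering group. The data show a 6.9-fold higher number from compound 2 to compound 3 (0.84 log units; beyond the scatter), a modest step, and a 12-fold lower number from compound 1 to compound 2 (1.07 log units; beyond the scatter), a large one, while a 1.7-fold lower number from compound 1 to compound 3 (0.23 log units; within the scatter) stays within the scatter. Going by the values given here, no measured compound carries 2-methylphenyl itself, so only part of that gap is expected to return in this assay, towards a lower number. The expected change is a 2.7-fold lower number from compound 3 to compound 4 (0.43 log units; beyond the scatter). Compound 4 is estimated at 3000 nM, with an expected range of 900 nM to 10000 nM.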

Compound 4, half-maximal inhibitory concentration: 40500 nM
Compound 4: middle estimate off by 14-fold (1.13 log units), on the low side; the measured number lies above the stated range.
By their numbers in this assay, from the lowest: compound 2; then compounds 3 and 1 (each within the scatter of the next); then compound 4.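

In this assay, the result for 2-fluorophenyl does not carry over to 2-methylphenyl: methyl in place of fluoro on this aromatic carbon gives a 35-fold higher number from compound 2 to compound 4 (1.54 log units; beyond the scatter), a larger step than any seen before. This change also places compound 4 highest of the four, with a 5.0-fold higher number from compound 3 to compound 4 (0.70 log units; beyond the scatter) and a 3.0-fold higher number from compound 1 to compound 4 (0.48 log units; beyond the scatter), so a group at this ring carbon does not by itself bring a low number. Nothing available explains this gap. From the compounds shown here alone, whether an amine, a hydroxyl or a methoxy group on that aromatic carbon would track compound 2 or compound 4 remains open.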